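The source may hold more compounds than are shown below. What is called first, only, known or untested is meant among the compounds shown, and "the series" means these compounds.

Compound 1 `CCCCCOc1nc(N)nc2c1ncn2/C=C1/CC1(CO)CO` and compound 2 `CCCCNc1nc(N)nc2c1ncn2/C=C1/CC1(CO)CO` share one core and were both tested in an ADME assay on MOLT-3 cells (Homo sapiens) for cytotoxicity, with a stated time of 7 days; on this read-out higher numbers stand for lower toxicity in this test and lower numbers for higher toxicity in this test. In this assay compound 1 reaches only a limit of the test, not a number, at > 20000 nM. Compound 2 likewise gives only a limit, > 20000 nM. The step from compound 1 to compound 2, a step that the two limits leave unreadable from compound 1 to compound 2, puts butylamino in place of pentyloxy on an aromatic carbon, and its size cannot be read since (the limit of > 20000 nM in this assay, at which 2 of the 3 values shown sit). Compound 3 `Nc1nc(N2CCCC2)c2ncn(/C=C3/CC3(CO)CO)c2n1` carries pyrrolidin-1-yl on that aromatic carbon; in this assay compound 3 stands at "not determined" (no result reported), so no number exists for it. Compound 4 `CCCCCCOc1nc(N)nc2c1ncn2/C=C1/CC1(CO)CO` differs from compound 3 in one place: hexyloxy in place of pyrrolidin-1-yl on an aromatic carbon. Within the data shown here, the only measured step, from compound 1 to compound 2, is unreadable, so no step beyond the scatter can be expected in either direction for this exchange. Compound 4 is therefore expected to sit at the same limit, with an estimate of 30000 nM and a range from 10000 nM to 100000 nM.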

Compound 4, half-maximal cytotoxic concentration: > 20000 nM
Compound 4 gave a limit, no number; the forecaster's own chance of this, stated with the estimate: 85%; the middle value does not contradict the limit.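

Compound 4, like compound 1 and compound 2, gives no number, so the steps to compound 4 from compound 1 and compound 2 cannot be read: the limit of > 20000 nM in this assay, at which 3 of the 4 values shown sit. The compounds shown leave open whether exchanging the group on that aromatic carbon changes toxicity in this test at all.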